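Changing one side group on a shared core

The source may hold more compounds than are shown below. What is called first, only, known or untested is meant among the compounds shown, and "the series" means these compounds.

Values in a functional assay on MCF7 cells (Homo sapiens) for inhibition, read by fluorescence, with a stated time of 72 h (a lower number here means a stronger inhibitor, a higher number a weaker inhibitor), follow
Compound 1 `CCn1cnc2c(NC(=N)N)nc(N)nc21` gives 54300 nM
Compound 2 `CC(C)[C@@H](N)COc1nc(NC(=N)N)c2ncn(C(C)C)c2n1` gives 79400 nM

Compound 2 at 79400 nM and compound 1 at 54300 nM lie within the usual scatter of each other, so these two numbers show no real difference. In compound 3 `CC(C)n1cnc2c(NC(=N)N)nc(N3CCC[C@@H]3CO)nc21`, 2-(hydroxymethyl)pyrrolidin-1-yl stands in place of 2-amino-3-methylbutoxy on an aromatic carbon between two ring nitrogen atoms (2-(hydroxymethyl)pyrrolidin-1-yl in place of 2-amino-3-methylbutoxy on an aromatic carbon). Within the data shown here, no measured pair isolates this change, so no step beyond the scatter is expected in this assay and the estimated move a 1.3-fold lower number from compound 2 to compound 3 (0.12 log units; within the scatter) stays small. For compound 3 the expected value is 60000 nM (estimated range 20000 nM to 130000 nM).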

Compound 3, half-maximal inhibitory concentration: 20400 nM
Compound 3: the middle estimate sits 2.9-fold (0.47 log units) above what was measured, and the stated range covers the measured number.
By their numbers in this assay, from the lowest: compound 3; then compounds 1 and 2 (each within the scatter of the next).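

In this assay, placing 2-(hydroxymethyl)pyrrolidin-1-yl instead of 2-amino-3-methylbutoxy on the aromatic carbon between two ring nitrogen atoms gives a 3.9-fold lower number from compound 2 to compound 3 (0.59 log units; beyond the scatter), so the number at this position responds to the side group. The two groups match in their counts of heavy atoms, donors and acceptors, so those counts do not separate them, while the entering group holds a ring. Nothing measured here gives a reason for the step. Still open, going by these compounds, is which part of the new group matters: a pyrrolidin-1-yl group without the hydroxymethyl, or a longer chain on the same carbon, would test this.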